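The source may hold more compounds than are shown below. What is called first, only, known or untested is meant among the compounds shown, and "the series" means these compounds.

For the measured compounds named here, compound 3 `CCN(C/C=C/C#CC(C)(C)C)Cc1cccc(OCCN(C)S(=O)(=O)Cc2cccs2)c1` is one of three compounds measured in a functional assay on HepG2 cells for inhibition of squalene monooxygenase (Homo sapiens) (a higher number here means a weaker inhibitor, a lower number a stronger inhibitor), where compound 3 gives 200 nM. Compound 2 `CCN(C/C=C/C#CC(C)(C)C)Cc1cccc(OCCN(C)S(=O)(=O)c2ccc(C#N)cc2)c1` gives 200 nM, and compound 1 `CCN(C/C=C/C#CC(C)(C)C)Cc1cccc(OCCNS(=O)(=O)c2cccs2)c1` gives 450 nM. Compound 3 thus shares the lowest number with compound 2, while the number rose a 2.3-fold lower number from compound 1 to compound 3 (0.35 log units; beyond the scatter) in reverse of that step. Compound 4 `CCN(C/C=C/C#CC(C)(C)C)Cc1cccc(OCCN(C)S(=O)(=O)c2ccc(Br)s2)c1` differs from compound 3 by 5-bromothiophen-2-yl in place of (thiophen-2-yl)methyl on a sulfonyl sulfur. Going by the values given here, the closest precedent is the change of the ring on the sulfonyl sulfur, which gave no change at the digits printed from compound 2 to compound 3 (within the scatter); the other step, a 2.3-fold lower number from compound 1 to compound 3 (0.35 log units; beyond the scatter), altered the chain instead. A swap of the aryl group at that position is therefore expected to leave this assay within the scatter, with an expected step of a 1.1-fold higher number from compound 3 to compound 4 (0.04 log units; within the scatter). Compound 4 is estimated at 220 nM, in a range from 90 nM to 550 nM.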

Compound 4, half-maximal inhibitory concentration: 390 nM
Beside the measured number, compound 4's estimate is 1.8-fold (0.25 log units) below it, within the range that was stated.
By their numbers in this assay, from the lowest: compounds 2, 3, 4 and 1 (each within the scatter of the next, the first and the last beyond it).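

In this assay the sulfonyl sulfur takes a third group, 5-bromothiophen-2-yl, with a 2.0-fold higher number from compound 3 to compound 4 (0.29 log units; within the scatter) and a 2.0-fold higher number from compound 2 to compound 4 (0.29 log units; within the scatter) as its steps, so these three groups cannot be told apart here. The step of a 1.2-fold lower number from compound 1 to compound 4 (0.06 log units; within the scatter) is also within the scatter, but it alters the sulfonamide nitrogen and the ring together, so it says little about either alone. Nothing measured here accounts for these numbers. Still open, on these data alone, is how a plain thiophen-2-yl or 5-chlorothiophen-2-yl would read with this same chain, and whether an amine or carboxylic acid on that ring would move the number beyond the scatter.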